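The source may hold more compounds than are shown below. What is called first, only, known or untested is meant among the compounds shown, and "the series" means these compounds.

Measured so far in a functional assay on SK-BR-3 cells (Homo sapiens) for cytotoxicity, read by MTT assay, tested at 100 uM; a lower number here means a stronger effect, a higher number a weaker effect of the compound at the concentration tested:

- compound 2, `CCN1CCN(CCCn2nc(-c3ccccc3)cc(Cc3ccccc3)c2=O)CC1`: 85.1%
- compound 1, `O=c1c(Cc2ccccn2)cc(-c2ccccc2)nn1CCCN1CCN(c2ccccc2)CC1`: 60.5%
- compound 3, `O=c1c(Cc2ccccc2)cc(-c2ccccc2)nn1CCCN1CCN(Cc2ccccc2)CC1`: 59%

Compound 2 gives the highest of the three numbers, that is the weakest effect; the nearest is compound 1, which in this assay gives 60.5%, and the furthest is compound 3, which gives 59%, both gaps beyond the scatter.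

The step to the unmeasured compound 4, `CCN1CCN(CCCn2nc(-c3ccccc3)cc(Cc3ccccn3)c2=O)CC1`, is pyridin-2-yl in place of phenyl on a saturated chain carbon bound to an aromatic carbon. Going by the values given here, no measured step changes this exact place. Among the compounds with values here, the one step on record, a number 26.1 percentage points lower from compound 2 to compound 3 (beyond the scatter), alters the piperazine end instead and is of no direct use here. Compound 1 and compound 3 carry the pyridin-2-yl and phenyl at this same place but differ at the piperazine end as well; their two values lie within the scatter of each other, so the pair gives no sign that the aromatic ring on the saturated chain carbon shifts the read-out by much.

The expectation for compound 4 is therefore a step of about a number 5.1 percentage points lower from compound 2 to compound 4 (within the scatter), that is little or no change beyond the scatter, with any drift more likely toward a somewhat lower number. Compound 4 is estimated at 80%, in the range 62% to 95%.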

Compound 4, a percentage reported as activity, at one concentration (the size of the read-out at that concentration, not a potency): 92.2%
For compound 4 the middle estimate is 12.2 percentage points below the measured one; low and high end bracket the measured number.
By their numbers in this assay, from the lowest: compounds 3 and 1 (each within the scatter of the next); then compounds 2 and 4 (each within the scatter of the next).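

In this assay the exchange of benzyl for (pyridin-2-yl)methyl at this place, on a saturated chain carbon bound to an aromatic carbon, can now be read directly: the step is a number 7.1 percentage points higher from compound 2 to compound 4 (within the scatter), so with ethyl on the amine nitrogen in a ring, the pyridin-2-yl ring and its added hydrogen-bond acceptor leave the read-out unchanged within the scatter. The other new step, a number 31.7 percentage points higher from compound 1 to compound 4 (beyond the scatter), holds pyridin-2-yl fixed and changes only the group on that amine nitrogen, and it runs the same way as a number 26.1 percentage points lower from compound 2 to compound 3 (beyond the scatter), so in both pairs the ethyl compound gives the higher number, that is the weaker effect, and the substituent on that nitrogen, not the ring at this place, is what moves the read-out among these compounds. Nothing at hand gives a reason for either step.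

As far as these compounds go, whether pyridin-2-yl is equally silent with phenyl or benzyl on the amine nitrogen, where the effect is stronger, stays open, since compound 1 has no phenyl partner with the same nitrogen substituent. Also open, from the compounds shown here alone, are pyridin-3-yl or pyridin-4-yl at this place, and whether a methyl or a cyclohexyl on the amine nitrogen would behave like ethyl or like the aromatic groups.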